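A few compounds are considered here, and "the series" means these few. Any claim that something is new, unique, unknown or untested is made for them only; others in the source may bear on it.

Measured compounds:
- compound 1, `CCCCc1ccc([C@H]2C[C@@H](Nc3nc4cc[nH]c4c(=O)n3C)CN(C)C2)cc1`, giving 183 nM in an assay on isolated protein for binding affinity to histone acetyltransferase KAT2B (Homo sapiens), read by isothermal titration calorimetry; a higher number here means weaker binding, a lower number tighter binding
- compound 2, `CN1C[C@H](Nc2nc3cc[nH]c3c(=O)n2C)C[C@H](c2ccccc2)C1`, giving 152 nM in this assay
- compound 3, `C=CCn1c(N[C@@H]2C[C@H](c3ccccc3)CN(C)C2)nc2cc[nH]c2c1=O`, giving 676 nM in this assay

Compound 2 has the lowest number of the three, though its gap to compound 1, a 1.2-fold lower number from compound 1 to compound 2 (0.08 log units; within the scatter), lies within the scatter, so the two cannot be ranked against each other; only compound 3 is clearly set apart, by a 4.4-fold higher number from compound 2 to compound 3 (0.65 log units; beyond the scatter).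

Compound 4, `CN1C[C@@H](Nc2nc3cc[nH]c3c(=O)n2C)C[C@@H](c2ccccc2)C1`, is not yet measured. It differs from compound 2 as follows: the two compounds have the same atoms and bonds and differ only in configuration as drawn: 2 of 2 stereo elements differ (all stereocentres are inverted: mirror images); a stereocentre at a saturated ring carbon is drawn R in compound 2 and S in compound 4; a stereocentre at a saturated ring carbon is drawn R in compound 2 and S in compound 4. Neither measured step bears on such a change: the step from compound 1 to compound 2 swaps a butyl for hydrogen on an aromatic carbon, and the step from compound 2 to compound 3 adds a vinyl on a saturated chain carbon bound to an aromatic nitrogen. For the measured compounds named here, nothing among the measured compounds shows how mirror-image configuration affects this assay. Mirror-image pairs often differ in binding, frequently with one partner weaker, but the direction cannot be read from these data. Compound 4 is therefore expected to give 1500 nM, within a wide range from 150 nM to 15000 nM, meaning an expected step of a 9.9-fold higher number from compound 2 to compound 4 (0.99 log units; beyond the scatter).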

Compound 4, dissociation constant: > 10000 nM
Compound 4 was reported as a limit (the forecaster's own chance of this, stated with the estimate: 10%); at least 6.6-fold (0.82 log units) between middle value and limit.
By their numbers in this assay, from the lowest: compounds 2 and 1 (each within the scatter of the next); then compound 3. At a limit, above all of these: compound 4.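

Inverting both stereocentres, with no atom or bond changed, gives an at least 65-fold higher number from compound 2 to compound 4 (1.81 log units; beyond the scatter). For the compounds shown here, this is the first sign that configuration matters in this assay, something the butyl and vinyl steps could not reveal, and it outweighs both of those steps. The value of compound 4, > 10000 nM, is a limit and not a number, and the gap can be put down to configuration and nothing else: the fact that compounds 2 and 4 differ only in the configuration as drawn.

Which of the two stereocentres counts, or whether both are needed, stays open, as does whether the mirror-image form of compound 1 or compound 3 would behave the same way. Also open, as far as these compounds go, is how binding in this assay would respond to a carboxylic acid in place of the butyl, or to a longer chain in place of the vinyl.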